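The compounds below may be only part of what the source reports. "The series", "measured", "known", "first", "only" and "open" are said of these compounds alone.

Measured so far:
compound 1 `CS(=O)(=O)CCCn1c(Cn2c(=O)n(C3CC3)c3ccncc32)nc2nc(Cl)ccc21` — > 50000 nM
compound 2 `N#CCCCn1c(Cn2c(=O)n(-c3ccc(C(=O)NC4CC4)cc3)c3ccncc32)cc2cc(Cl)ccc21` — > 50000 nM
compound 3 `CS(=O)(=O)CCCn1c(Cn2c(=O)n(CC#N)c3ccncc32)cc2cc(Cl)ccc21` — > 50000 nM

In an ADME assay on HeLa cells (Homo sapiens) for cytotoxicity, read by ATP content, with a stated time of 3 days (on this read-out higher numbers stand for lower toxicity in this test and lower numbers for higher toxicity in this test), compound 1 gives > 50000 nM, which is a limit of the assay and not a number. Compound 2 gives > 50000 nM, likewise a limit. Compound 3 gives > 50000 nM, also a limit. Compound 2 thus stands at the limit of > 50000 nM in this assay, at which 3 of the 3 values shown sit; no numbered value sets it apart from the other two. Compound 4 `COc1ccc(-n2c(=O)n(Cc3cc4cc(Cl)ccc4n3CCCC#N)c3cnccc32)cc1OC` is not yet measured. It differs from compound 2 by 3,4-dimethoxyphenyl in place of 4-(cyclopropylcarbamoyl)phenyl on an aromatic nitrogen. Within the data shown here, no measured pair isolates this change, so no step size follows from the data. With every value in the set a limit, the step of a number no higher from compound 2 to compound 4 (the limit leaves the size open) is expected to lie within the scatter. Compound 4 is expected to give 50000 nM, in the range 20000 nM to 100000 nM, most probably reported again only as a limit.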

Compound 4, half-maximal cytotoxic concentration: > 50000 nM
Compound 4: no number, only a limit (the forecaster's own chance of this, stated with the estimate: 85%); the middle value lies on the limit itself.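

In this assay compound 4 gives > 50000 nM, a limit and not a number. Compound 2 also stands at a limit, and no step can be read between compound 2 and compound 4. The actual half-maximal cytotoxic concentration of each compound shown stays open: the limit of > 50000 nM in this assay, at which 4 of the 4 values shown sit.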